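Piperidinyl Replaces Morpholinyl on the Thiocarbonyl Carbon

A few compounds are considered here, and "the series" means these few. Any claim that something is new, unique, unknown or untested is made for them only; others in the source may bear on it.

Compound 2 `COc1ccc2occ(CSC(=S)N3CCOCC3)c(=O)c2c1` is the starting point. In a functional assay on MDA-MB-435S cells (Homo sapiens) for antiproliferative activity, read by MTT assay, with a stated time of 72 h (a lower number here means a stronger inhibitor, a higher number a weaker inhibitor), compound 2 gives only a limit, > 40000 nM. Compound 1 `COc1ccc2occ(CSC(=S)N(C(C)C)C(C)C)c(=O)c2c1` gives 1800 nM in this assay, and compound 3 `O=c1c(CSC(=S)N2CCOCC2)coc2ccccc12` gives 3900 nM. Compound 4 `COc1ccc2occ(CSC(=S)N3CCCCC3)c(=O)c2c1` is not yet measured; its difference from compound 2 is piperidin-1-yl in place of morpholin-4-yl on a thiocarbonyl carbon. Among the measured compounds shown here, two measured steps bear on this change: an at least 22-fold higher number from compound 1 to compound 2 (1.34 log units; beyond the scatter), and an at least 10-fold lower number from compound 2 to compound 3 (1.01 log units; beyond the scatter). Both are large, and both stand against the limit (the limit of > 40000 nM in this assay, at which 1 of the 3 values shown sits). The change to compound 4 also removes morpholin-4-yl from the thiocarbonyl carbon, the group whose entry gave an at least 22-fold higher number from compound 1 to compound 2 (1.34 log units; beyond the scatter). For compound 4 a large downward step is therefore expected, an at least 8.0-fold lower number from compound 2 to compound 4 (0.90 log units; beyond the scatter). Compound 4 is estimated near 5000 nM, within a range from 1500 nM to 30000 nM.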

Compound 4, half-maximal inhibitory concentration: 930 nM
The estimate for compound 4 lay 5.4-fold (0.73 log units) above the measured number, and the stated range ends above it.
By their numbers in this assay, from the lowest: compounds 4 and 1 (each within the scatter of the next); then compound 3. At a limit, above all of these: compound 2.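

Exchanging morpholin-4-yl for piperidin-1-yl on the thiocarbonyl carbon gives an at least 43-fold lower number from compound 2 to compound 4 (1.63 log units; beyond the scatter), so in this assay a ring at this place does not by itself carry the loss seen with compound 2. That step stands against a limit, not a number: the limit of > 40000 nM in this assay, at which 1 of the 4 values shown sits.

Diisopropylamino and piperidin-1-yl cannot be told apart here, with a 1.9-fold lower number from compound 1 to compound 4 (0.29 log units; within the scatter).

The compounds shown leave open how a piperazine, a pyrrolidine or a dimethylamino group would fare on this carbon. They also leave open whether piperidin-1-yl would give a similar result on the core of compound 3, which carries hydrogen in place of methoxy.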